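Swapping a 3-hydroxyphenyl for a 2-nitrophenyl on the shared core

This account rests on a few compounds, and the source may have more. Where it says the series, first, only, none or still open, it means among the compounds named here.

Compound 3 `CC1=C(C(=O)OCc2cccnc2)C(c2cccc(O)c2)C2=C(CCCC2=O)N1` gives 1.21 in a physicochemical assay for lipophilicity, measured as octanol-water partition (on this read-out lower numbers stand for lower lipophilicity and higher numbers for higher lipophilicity), and is the reference point here. Compound 1 `CC1=C(C(=O)OCc2cccnc2)C(c2ccc(C#N)cc2)C2=C(CCCC2=O)N1` gives 1.36 in the same measurement, and these two numbers lie within the scatter of each other. Compound 2 `CC1=C(C(=O)OCc2ccccn2)C(c2cccc(O)c2)C2=C(CCCC2=O)N1` gives 1.58 and stands clearly above compound 3 on this scale.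

The compound still to be measured is compound 4 `CC1=C(C(=O)OCc2cccnc2)C(c2ccccc2[N+](=O)[O-])C2=C(CCCC2=O)N1` which carries 2-nitrophenyl in place of 3-hydroxyphenyl on a saturated ring carbon while the rest of the molecule stays the same.

Within the data shown here, only one measured step changes the group at this carbon. Replacing 4-cyanophenyl with 3-hydroxyphenyl gave a number 0.15 log units lower from compound 1 to compound 3 (within the scatter) and so offers no sign of a large effect at this position. The pyridin-3-yl in place of pyridin-2-yl step gave a number 0.37 log units lower from compound 2 to compound 3 (beyond the scatter) but it lies elsewhere in the molecule and bears on this change only as a guide to size. Among the measured compounds shown here, no measured compound carries a 2-nitrophenyl, so the slight upward lean here is a judgement. The expected step is a number 0.24 log units higher from compound 3 to compound 4 (within the scatter) as an estimate in this assay for now. The estimated value for compound 4 is 1.45 with an expected range from 1.05 to 1.85 until the measurement arrives.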

Compound 4, partition coefficient: 1.51
The estimate for compound 4 lay 0.06 log units below the measured number; measured number inside the range.
By their numbers in this assay, from the lowest: compounds 3, 1, 4 and 2 (each within the scatter of the next, the first and the last beyond it).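

In this assay, among these compounds, the swap of 3-hydroxyphenyl for 2-nitrophenyl gave a number 0.30 log units higher from compound 3 to compound 4 (within the scatter) and the swap of 4-cyanophenyl for 2-nitrophenyl gave a number 0.15 log units higher from compound 1 to compound 4 (within the scatter), so no step among the three groups now measured on this saturated ring carbon goes beyond the scatter. This holds even though the entering 2-nitrophenyl has 0 hydrogen-bond donors and 9 heavy atoms, while the leaving 3-hydroxyphenyl has 1 hydrogen-bond donor and 7 heavy atoms. The one step shown beyond the scatter is still a number 0.37 log units lower from compound 2 to compound 3 (beyond the scatter) and it comes from the pyridinyl change elsewhere in the molecule, not from a change at this carbon.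

Still open, on these data alone, is whether a plain phenyl, or a phenyl carrying an amine or a carboxylic acid, would give a number clearly apart from these, and whether 2-nitrophenyl would give a similar step alongside the pyridin-2-yl group of compound 2. No measurement is available to explain why these three groups give numbers so close together.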